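Swapping Cyclopentyl for Cyclopropylmethyl on the Ring Nitrogen

The source may hold more compounds than are shown below. What is called first, only, known or untested is meant among the compounds shown, and "the series" means these compounds.

Compound 1 `CN1CCN(c2ccc(Nc3ncc4nc(Sc5ccccc5)n(C5CCCC5)c4n3)cc2)CC1`: 51.2 nM
Compound 2 `CN1CCN(c2ccc(Nc3ncc4nc(SCc5cccnc5)n(C5CCCC5)c4n3)cc2)CC1`: 517 nM
Compound 3 `CN1CCN(c2ccc(Nc3ncc4nc([S+]([O-])c5ccccc5)n(C5CCCC5)c4n3)cc2)CC1`: 64.7 nM

In a functional assay on HCC827 cells (Homo sapiens) for antiproliferative activity, read by MTT assay, with a stated time of 72 h (a lower number here means a stronger inhibitor, a higher number a weaker inhibitor), compound 1 gives the lowest of the three numbers. Compound 3 sits close to it, a 1.3-fold higher number from compound 1 to compound 3 (0.10 log units; within the scatter), while compound 2 lies well apart, a 10-fold higher number from compound 1 to compound 2 (1.00 log units; beyond the scatter). Compound 4 `CN1CCN(c2ccc(Nc3ncc4nc(Sc5ccccc5)n(CC5CC5)c4n3)cc2)CC1` has not yet been measured. It differs from compound 1 only in cyclopropylmethyl in place of cyclopentyl on an aromatic nitrogen. Among the compounds with values here, every measured step alters the group on the sulfur and none touches the aromatic nitrogen, so no step speaks directly to this change; the sulfur steps span from within the scatter up to an 8.0-fold lower number from compound 2 to compound 3 (0.90 log units; beyond the scatter). Without a direct guide, only a small shift is expected, leaning toward a slightly higher number: a 2.3-fold higher number from compound 1 to compound 4 (0.37 log units; beyond the scatter). Compound 4 is therefore expected to give 120 nM, within 40 nM to 400 nM.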

Compound 4, half-maximal inhibitory concentration: 660 nM
The estimate for compound 4 lay 5.5-fold (0.74 log units) below the measured number, outside the stated range (above it).
By their numbers in this assay, from the lowest: compounds 1 and 3 (each within the scatter of the next); then compounds 2 and 4 (each within the scatter of the next).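

The earlier compounds shown here changed only the group on the sulfur. Here the phenylsulfanyl group stays fixed, and in this assay cyclopropylmethyl in place of cyclopentyl on the aromatic nitrogen gives a 13-fold higher number from compound 1 to compound 4 (1.11 log units; beyond the scatter) and so shows that the group at this position also strongly affects the number. Nothing available here explains this loss of activity. As far as these compounds go, it remains open whether the number depends on ring size, on the carbon link between ring and nitrogen, or on both. Cyclobutyl, cyclohexyl or an open chain such as isopropyl on this nitrogen could help separate these possibilities.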